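From fluoro to chloro at a half-life limit

The source may hold more compounds than are shown below. What is called first, only, known or untested is meant among the compounds shown, and "the series" means these compounds.

Compound 1 `Nc1nc(NCCNc2ncc(-c3ncc[nH]3)c(-c3ccc(F)cc3F)n2)ccc1[N+](=O)[O-]` gives > 0.5 h as a limit
Compound 2 `Nc1nc(NCCNc2ncc(-c3ncc[nH]3)c(-c3cc(F)ccc3F)n2)ccc1[N+](=O)[O-]` gives > 0.5 h as a limit
Compound 3 `Nc1nc(NCCNc2ncc(-c3ncc[nH]3)c(-c3ccc(F)cc3Br)n2)ccc1[N+](=O)[O-]` gives > 0.5 h as a limit

All three readings come from an ADME assay on microsomes from liver (Canis lupus familiaris) for metabolic stability (on this read-out higher numbers stand for a longer-lived compound and lower numbers for a shorter-lived compound), and none of them is an exact number. Compound 3 stands at > 0.5 h and that is a limit. The series as a whole shows the limit of > 0.5 h in this assay, at which 3 of the 3 values shown sit, and nothing finer.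

Compound 4 `Nc1nc(NCCNc2ncc(-c3ncc[nH]3)c(-c3ccc(Cl)cc3Br)n2)ccc1[N+](=O)[O-]` has not yet been measured. It departs from compound 3 by one change, chloro in place of fluoro on an aromatic carbon and in words this is chloro in place of fluoro on an aromatic carbon, turning 2-bromo-4-fluorophenyl into 2-bromo-4-chlorophenyl.

Among the measured compounds shown here, three measured steps bear on this change. The nearest is bromo in place of fluoro on an aromatic carbon, which appears as a step that the two limits leave unreadable from compound 1 to compound 3 and gives no size to carry over. The other two read a step that the two limits leave unreadable from compound 1 to compound 2 and a step that the two limits leave unreadable from compound 2 to compound 3 and are no more informative. With a step that the two limits leave unreadable from compound 1 to compound 3 as the nearest guide, no direction is expected in this assay and no step beyond the usual scatter is expected either. The expected outcome is a step that the limit leaves unreadable from compound 3 to compound 4 on this reasoning. For compound 4 the estimated half-life is 0.8 h with an expected range from 0.4 h to 2 h on this reading.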

Compound 4, half-life: > 0.5 h
Compound 4: a limit, no number; the forecaster's own chance of this, stated with the estimate: 75%; the middle value does not contradict the limit.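

In this assay compound 4 gives > 0.5 h, which is a limit. Among the compounds shown here, its steps from compound 1, compound 2 and compound 3 cannot be read, so this result yields no new step. The compounds shown leave open how long any of them lasts, and whether chloro in place of fluoro makes any difference, with every reading resting on one value: the limit of > 0.5 h in this assay, at which 4 of the 4 values shown sit.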